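Lengthening the hydroxymethyl chain of compound 1

The source may report more compounds than this note shows. Statements on the series, on what has been measured and on what is new or still open speak of the compounds shown alone.

compound 1 `OCc1cn(Cc2ccc(Cl)cc2)c2ccccc12` gives 79 nM 
compound 2 `OCc1cn(Cc2ccc(Cl)c(Cl)c2)c2ccccc12` gives 310 nM 

In a functional assay on T29Kt1 cells (Homo sapiens) for cytotoxicity, read by sulforhodamine B assay, with a stated time of 3 days (on this read-out higher numbers stand for weaker inhibition and lower numbers for stronger inhibition), compound 1 holds the lower of the two numbers at 79 nM and is the better of this pair. Compound 3 `OCCc1cn(Cc2ccc(Cl)cc2)c2ccccc12` is the next to be measured. Its difference from compound 1 is hydroxymethyl in place of hydroxy on a saturated chain carbon bound to an aromatic carbon on a saturated chain carbon bound to an aromatic carbon, which also reads as hydroxymethyl to 2-hydroxyethyl. Among the measured compounds shown here, only one measured step exists, a 3.9-fold higher number from compound 1 to compound 2 (0.59 log units; beyond the scatter), and it is modest. For the measured compounds named here, that step is a different change, chloro in place of hydrogen on an aromatic carbon, so it bears only loosely on this one, and no measured compound varies the chain. A modest move to a higher number is therefore expected in this assay, though with wide uncertainty. The expected step is a 3.2-fold higher number from compound 1 to compound 3 (0.50 log units; beyond the scatter) in this estimate. Compound 3 is estimated at 250 nM with an expected range of 60 nM to 1500 nM in this assay.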

Compound 3, half-maximal inhibitory concentration: > 31600 nM
Compound 3: no number, only a limit (the forecaster's own chance of this, stated with the estimate: 5%); middle value at least 120-fold (2.10 log units) from the limit.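

Among the compounds shown here, this position turns out to be far less forgiving than the only earlier step, the modest chloro change, could show: in this assay, going from hydroxymethyl to 2-hydroxyethyl gives an at least 400-fold higher number from compound 1 to compound 3 (2.60 log units; beyond the scatter). The reading for compound 3 is a limit of the assay and not a number: the limit of > 31600 nM in this assay, at which 1 of the 3 values shown sits. The pair therefore marks the hydroxymethyl of compound 1 as a sensitive point of the series, though the size of the step stays open-ended and the data give no cause for it.

The compounds shown do not tell whether the drop follows from the chain length or from where the hydroxy group ends up. An amine, a carboxylic acid or a methyl ether at this place could separate the two, and the same chain change on the core of compound 2 would show whether the effect carries over.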